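From furan-3-yl to iodo on a shared core

The compounds below may be only part of what the source reports. "The series", "measured", "known", "first", "only" and "open" are said of these compounds alone.

Values in a functional assay on CCRF-CEM cells (Homo sapiens), read by MTT assay, with a stated time of 72 h (on this read-out lower numbers stand for stronger inhibition and higher numbers for weaker inhibition), are as follows.
Compound 1 `Cc1nc(N)c2c(-c3ccoc3)cn([C@@H]3O[C@H](CO)[C@@H](O)[C@H]3O)c2n1` gives > 100000 nM (a limit, not a number)
Compound 2 `Nc1nc2c(c(-c3ccoc3)cn2[C@@H]2O[C@H](CO)[C@@H](O)[C@H]2O)c(=O)[nH]1` gives 17900 nM

Compound 1 thus stands at the limit of > 100000 nM in this assay, at which 1 of the 2 values shown sits. Compound 3 `Cc1nc(N)c2c(I)cn([C@@H]3O[C@H](CO)[C@@H](O)[C@H]3O)c2n1` differs from compound 1 by one change, iodo in place of furan-3-yl on an aromatic carbon. Within the data shown here, no measured pair shows this change, so the expectation is loose. The step of an at least 3.3-fold lower number from compound 1 to compound 3 (0.52 log units; beyond the scatter) is expected to run toward stronger inhibition, and its size is uncertain. Compound 3 is estimated at 30000 nM, with an expected range from 3000 nM to 100000 nM.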

Compound 3, half-maximal inhibitory concentration: 9030 nM
Estimate against measurement, compound 3: 3.3-fold (0.52 log units) above; measured number inside the range.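

In this assay, iodo in place of furan-3-yl on this aromatic carbon of the shared core brings an at least 11-fold lower number from compound 1 to compound 3 (1.04 log units; beyond the scatter). The read-out at this position therefore responds to the change, and a group with no ring gives a measured number where the furan-3-yl compound gives none. The step is a bound and not an exact size, since compound 1 stands at a limit: the limit of > 100000 nM in this assay, at which 1 of the 3 values shown sits.

As far as these compounds go, it remains open how an amine or a phenyl group on this carbon would compare with iodo. From the compounds shown here alone, whether iodo brings a similar step on the core of compound 2 also remains open.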